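The source may report more compounds than this note shows. Statements on the series, on what has been measured and on what is new or still open speak of the compounds shown alone.

Measured compounds:
- compound 1, `Oc1ccc(-c2cc(-c3cccs3)cc(-c3ccccc3O)n2)cc1`: > 50000 nM
- compound 2, `Oc1ccc(-c2cc(-c3cccs3)cc(-c3cccc(O)c3)n2)cc1`: 1890 nM
- compound 3, `Oc1cccc(-c2cc(-c3ccccn3)cc(-c3ccccc3O)n2)c1`: 17100 nM

In a functional assay on DU-145 cells (Homo sapiens) for cytotoxicity, read by CCK-8 assay (a lower number here means a stronger inhibitor, a higher number a weaker inhibitor), compound 1 gives only a limit, > 50000 nM, and no number. Compound 2 gives 1890 nM in this assay. Compound 3 gives 17100 nM, the highest of the two numbers shown, with compound 2 as its nearest neighbour. Within the data shown here, the one measured step is an at least 26-fold lower number from compound 1 to compound 2 (1.42 log units; beyond the scatter), made by the change (3-hydroxyphenyl in place of 2-hydroxyphenyl on an aromatic carbon). Its size is known only as a lower bound because of the limit of > 50000 nM in this assay, at which 1 of the 3 values shown sits. How the core of compound 1 and the core of compound 3 differ is not broken down here.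

Compound 4, `Oc1cccc(-c2cc(-c3ccccn3)cc(-c3cccc(O)c3)n2)c1`, is not yet measured. It arises from compound 3 by 3-hydroxyphenyl in place of 2-hydroxyphenyl on an aromatic carbon. This is the same kind of change as that from compound 1 to compound 2, but the surroundings of the place differ: in compound 3 the place is meta to a 3-hydroxyphenyl group and meta to a pyridin-2-yl group, whereas in compound 1 it is meta to a 4-hydroxyphenyl group and meta to a thiophen-2-yl group. The expected step in this assay is an 11-fold lower number from compound 3 to compound 4 (1.06 log units; beyond the scatter), set beside the measured one and resting on compound 3 at 17100 nM together with the earlier step of an at least 26-fold lower number from compound 1 to compound 2 (1.42 log units; beyond the scatter). Compound 4 is accordingly estimated at 1500 nM, expected to lie between 400 nM and 6000 nM.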

Compound 4, half-maximal inhibitory concentration: 3610 nM
The estimate for compound 4 lay 2.4-fold (0.38 log units) below the measured number, and the stated range covers the measured number.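

In this assay, putting 3-hydroxyphenyl in place of 2-hydroxyphenyl again lowers the number, with a 4.7-fold lower number from compound 3 to compound 4 (0.68 log units; beyond the scatter) as the new step. The direction of the change thus carries from the core of compound 1 to the core of compound 3, but its size does not carry over unchanged: the same change on two cores in this assay, an at least 26-fold lower number (1.42 log units; beyond the scatter) from compound 1 to compound 2 and a 4.7-fold lower number (0.68 log units; beyond the scatter) from compound 3 to compound 4, at least 5.5-fold (0.74 log units) apart, beyond the scatter of two such steps. Compound 1 gives a limit and no number, so the earlier step is known only as a lower bound, and these two pairs do not show which of the differences between the cores governs the size of the change: the limit of > 50000 nM in this assay, at which 1 of the 4 values shown sits.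

The compounds shown leave open how the thiophen-2-yl and pyridin-2-yl groups and the 4-hydroxyphenyl and 3-hydroxyphenyl groups each contribute to the size of the step, as the two cores differ in more than one place. From the compounds shown here alone, it also remains open whether the hydroxyl group of the 3-hydroxyphenyl group is itself needed for the lower number in this assay, a question that a methoxy group or an amine in its place would address.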